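The source may hold more compounds than are shown below. What is called first, only, known or untested is meant among the compounds shown, and "the series" means these compounds.

In a functional assay on SW-620 cells (Homo sapiens) for antiproliferative activity, read by MTT assay, with a stated time of 72 h (on this read-out lower numbers stand for stronger inhibition and higher numbers for weaker inhibition), the three measured compounds stand as follows, each at a limit of the assay rather than a number:

Compound 1 `O=C1O/C(=C\Cn2cc(-c3ccc(Br)cc3)nn2)C(OCc2ccccc2)=C1OCc1ccccc1`: > 100000 nM
Compound 2 `CCCCCc1ccc(-c2cn(C/C=C3\OC(=O)C(OCc4ccccc4)=C3OCc3ccccc3)nn2)cc1`: > 100000 nM
Compound 3 `COc1ccc(-c2cn(C/C=C3\OC(=O)C(OCc4ccccc4)=C3OCc3ccccc3)nn2)cc1`: > 100000 nM

Within the data shown here, compound 3 therefore sits at the limit of > 100000 nM in this assay, at which 3 of the 3 values shown sit, and no measured compound stands apart from it. The steps a step that the two limits leave unreadable from compound 1 to compound 3 and a step that the two limits leave unreadable from compound 2 to compound 3 are both unreadable, and a step that the two limits leave unreadable from compound 1 to compound 2 is unreadable as well, so the ring substituent on the aryl group has left no readable mark in this assay. Compound 4 `O=C1O/C(=C\Cn2cc(-c3cccc(O)c3)nn2)C(OCc2ccccc2)=C1OCc1ccccc1` carries 3-hydroxyphenyl in place of 4-methoxyphenyl on an aromatic carbon. Since every measured step to compound 3 is unreadable, no size or direction can be drawn from them for this change. Compound 4 is expected to remain at the limit in this assay, estimated at 100000 nM with a range from 30000 nM to 300000 nM. The expected step of a number no higher from compound 3 to compound 4 (the limit leaves the size open) is thus none beyond the scatter.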

Compound 4, half-maximal inhibitory concentration: 69800 nM
For compound 4 the middle estimate is 1.4-fold (0.16 log units) above the measured one; the measured number falls inside the stated range.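

Compound 4 is the only one of the compounds shown that gives a number rather than a limit in this assay: the limit of > 100000 nM in this assay, at which 3 of the 4 values shown sit. With 3-hydroxyphenyl at this place on the five-membered ring, the steps read an at least 1.4-fold lower number from compound 3 to compound 4 (0.15 log units; that floor lies within the scatter), an at least 1.4-fold lower number from compound 2 to compound 4 (0.15 log units; that floor lies within the scatter) and an at least 1.4-fold lower number from compound 1 to compound 4 (0.15 log units; that floor lies within the scatter). Each gives a direction and a floor only, while the steps among the other three compounds cannot be read.

The change alters both the oxygen substituent and its place on the phenyl ring, and the compounds shown do not separate these two. On these data alone, whether an amine in place of the hydroxy group would also give a number stays open.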